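The source may hold more compounds than are shown below. What is called first, only, known or untested is meant among the compounds shown, and "the series" means these compounds.

In a functional assay on MCF7 cells (Homo sapiens) for inhibition, read by MTT assay, with a stated time of 72 h (on this read-out higher numbers stand for weaker inhibition and lower numbers for stronger inhibition), compound 1 `COc1cc(NC(C)CCCNC(=O)Nc2ccc(Br)cc2)c2ncccc2c1` gives 2600 nM, compound 3 `COc1cc(NC(C)CCCNC(=O)Nc2cc(C(F)(F)F)cc(C(F)(F)F)c2)c2ncccc2c1` gives 1600 nM, and compound 2 `COc1cc(NC(C)CCCNC(=O)NNC(=O)Nc2ccc(F)cc2)c2ncccc2c1` gives 310 nM, the lowest of these three numbers. Compound 4 `COc1cc(NC(C)CCCNC(=O)Nc2ccc(C(F)(F)F)cc2)c2ncccc2c1` has not yet been measured. It carries 4-(trifluoromethyl)phenyl in place of ((4-fluorophenyl)carbamoyl)amino on an amide-type nitrogen of compound 2 (4-(trifluoromethyl)phenyl in place of ((4-fluorophenyl)carbamoyl)amino on an amide-type nitrogen). Among the measured compounds shown here, one measured step bears on this change: an 8.4-fold lower number from compound 1 to compound 2 (0.92 log units; beyond the scatter), where ((4-fluorophenyl)carbamoyl)amino took the place of 4-bromophenyl. The change to compound 4 removes that same group, so a modest move to a higher number in this assay, of similar size, is expected. The expected step is a 6.5-fold higher number from compound 2 to compound 4 (0.81 log units; beyond the scatter). Compound 4 is estimated at 2000 nM, with an expected range of 800 nM to 4500 nM.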

Compound 4, half-maximal inhibitory concentration: 1900 nM
Compound 4: middle estimate off by 1.1-fold (0.02 log units), on the high side; measured number inside the range.
By their numbers in this assay, from the lowest: compound 2; then compounds 3, 4 and 1 (each within the scatter of the next).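

In this assay the change from ((4-fluorophenyl)carbamoyl)amino to 4-(trifluoromethyl)phenyl on the amide-type nitrogen gives a 6.1-fold higher number from compound 2 to compound 4 (0.79 log units; beyond the scatter) and so repeats, with a second entering group, the gap first seen with 4-bromophenyl. Trifluoromethyl in place of bromo on an aromatic carbon gives a 1.4-fold lower number from compound 1 to compound 4 (0.14 log units; within the scatter) and so does not separate these two groups on this read-out. No measurement shown accounts for the gap. Still open, from the compounds shown here alone, is how 4-fluorophenyl directly on that nitrogen, or ((4-(trifluoromethyl)phenyl)carbamoyl)amino there, would read.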